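Aryl variation on a shared core: cytotoxicity notes

The source may hold more compounds than are shown below. What is called first, only, known or untested is meant among the compounds shown, and "the series" means these compounds.

Measured compounds:
compound 1 `CCOC(=O)C12C(=O)OCC=C1COC2c1ccc(F)cc1`: in a functional assay on A549 cells (Homo sapiens) for cytotoxicity, read by MTT assay (on this read-out higher numbers stand for weaker inhibition and lower numbers for stronger inhibition), compound 1 gives > 1000000 nM, a limit of the assay.
compound 2 `CCOC(=O)C12C(=O)OCC=C1COC2c1ccc(OC)c(OC)c1`: in this assay compound 2 gives > 1000000 nM, again a limit.
compound 3 `CCOC(=O)C12C(=O)OCC=C1COC2c1cc(OC)cc(OC)c1`: in this assay compound 3 gives > 1000000 nM, also a limit.

Compound 1 therefore stands nowhere distinct among the numbers shown: all three values are limits, as summarised by the limit of > 1000000 nM in this assay, at which 3 of the 3 values shown sit, and no compound can be placed above or below another. Among the measured compounds shown here, no step between two measured compounds exists, so the series gives no measured step size or direction to lean on.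

Compound 4 `CCOC(=O)C12C(=O)OCC=C1COC2c1ccc(N(C)C)cc1` is the open member. Compared with compound 1 it carries dimethylamino in place of fluoro on an aromatic carbon. The three measured aryl variants, with fluoro or with one or two methoxy groups, all fail to reach a measurable value, and nothing in the data singles out the aromatic substituent as a driver of the read-out.

The expectation for compound 4 is a step from compound 1 of a step that the limit leaves unreadable from compound 1 to compound 4, that is, none beyond the scatter. Compound 4 is estimated at 2000000 nM, with a range from 300000 nM to 10000000 nM, and the assay is expected most likely to report only a limit again.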

Compound 4, half-maximal inhibitory concentration: 89600 nM
For compound 4 the middle estimate is 22-fold (1.35 log units) above the measured one; measured number outside the range, below it.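

The position on the aromatic ring, para to a large group, is not silent: with dimethylamino in place of fluoro on this aromatic carbon, this assay shows an at least 11-fold lower number from compound 1 to compound 4 (1.04 log units; beyond the scatter). Among the compounds shown here, compound 4 is the only compound here to give a measured number rather than a limit, so the aromatic substituent can move this read-out, which the fluoro and methoxy variants alone could not show. The full size of the step cannot be read, because compound 1 is itself only a limit, and it shares that limit with the other two aryl variants: the limit of > 1000000 nM in this assay, at which 3 of the 4 values shown sit.

The compounds shown leave open whether the step follows the nitrogen of the dimethylamino group or simply the larger group, since the change brings in both, and a plain amino group or an all-carbon isopropyl group at the same place would help separate the two. Also open, from the compounds shown here alone, is whether longer amines, such as diethylamino or a morpholine, take the number lower still or return it to the limit.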